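The compounds below may be only part of what the source reports. "The series", "measured", "known", "first", "only" and "open" are said of these compounds alone.

Values measured in (a functional assay on MCF7 cells (Homo sapiens) for cytotoxicity, read by ELISA, with a stated time of 4 days; on this read-out higher numbers stand for weaker inhibition and lower numbers for stronger inhibition):

- Compound 1 `Cc1ccccc1-c1cc(-c2ccoc2)cc(-c2ccc(Cl)s2)n1` (1430 nM)
- Compound 2 `Cc1ccc(-c2cc(-c3ccoc3)cc(-c3ccc(Cl)s3)n2)cc1` (5340 nM)
- Compound 3 `Clc1ccc(-c2cc(-c3ccoc3)cc(-c3ccc(Cl)s3)n2)cc1` (2600 nM)

Compound 3 cannot be told apart from one of its neighbours (a 1.8-fold higher number from compound 1 to compound 3 (0.26 log units; within the scatter)) and lies modestly lower than the other (a 2.1-fold lower number from compound 2 to compound 3 (0.31 log units; beyond the scatter)). In compound 4 `Clc1ccc(-c2cc(-c3ccoc3)cc(-c3cccnc3)n2)s1`, not yet measured, pyridin-3-yl stands in place of 4-chlorophenyl on an aromatic carbon (pyridin-3-yl in place of 4-chlorophenyl on an aromatic carbon). All three measured steps changed the group at this same place on the shared core, and the largest of them was only modest (a 3.7-fold higher number from compound 1 to compound 2 (0.57 log units; beyond the scatter)). Those steps only exchange one substituted phenyl for another, however. Going by the values given here, no measured compound carries a pyridine ring at this place, so the data give no firm direction. A step beyond the scatter is therefore not expected in this assay, in either direction. The estimated change is small (a 1.3-fold higher number from compound 3 to compound 4 (0.13 log units; within the scatter)). Compound 4 is expected near 3500 nM, with an estimated range from 1200 nM to 10000 nM.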

Compound 4, half-maximal inhibitory concentration: 3480 nM
For compound 4 the middle estimate is 1.0-fold (0.00 log units) above the measured one; measured number inside the range.
By their numbers in this assay, from the lowest: compounds 1, 3, 4 and 2 (each within the scatter of the next, the first and the last beyond it).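

Pyridin-3-yl is the first group at this place that is more than one substituted phenyl exchanged for another, and it brings a ring nitrogen and a hydrogen-bond acceptor. Even so, in this assay it cannot be told apart from either the 4-chlorophenyl group (a 1.3-fold higher number from compound 3 to compound 4 (0.13 log units; within the scatter)) or the 4-methylphenyl group (a 1.5-fold lower number from compound 2 to compound 4 (0.19 log units; within the scatter)), and only the comparison with 2-methylphenyl (a 2.4-fold higher number from compound 1 to compound 4 (0.39 log units; beyond the scatter)) shows a modest difference. Nothing measured here accounts for how small these differences are.

Still open, from the compounds shown here alone, is whether an amine, a carboxylic acid or a longer alkyl chain at this place would shift the number further than these aromatic rings do. Going by these compounds, the furan-3-yl and 5-chlorothiophen-2-yl groups stay the same throughout, so the effect of changing either remains unknown.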